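A Nitrile-for-Chloride Swap on the Cyclopropane Aryl Group

The source may hold more compounds than are shown below. What is called first, only, known or untested is meant among the compounds shown, and "the series" means these compounds.

Measured compounds:
compound 1 `NC1(CN(C(=O)[C@@H]2C[C@H]2c2ccccc2)c2ccc(-c3ccccc3)cc2)CCCC1` gives 0.57 nM
compound 2 `CCC(C)CNCCN(C(=O)[C@@H]1C[C@H]1c1ccccc1)c1ccc(-c2ccccc2)cc1` gives 4.7 nM
compound 3 `CC[C@H](C)[C@H](N)CN(C(=O)[C@@H]1C[C@H]1c1cccc(Cl)c1)c1ccc(-c2ccccc2)cc1` gives 2200 nM

In a functional assay for agonist activity at G protein-coupled receptor 88 (Homo sapiens), read by HTRF and cAMP accumulation (on this read-out lower numbers stand for an effect already at smaller amounts and higher numbers for an effect only at larger amounts of compound), compound 3 stands with the highest number of the three, far from compound 2 and further still from compound 1. Compound 4 `CC[C@H](C)[C@H](N)CN(C(=O)[C@@H]1C[C@H]1c1ccc(C#N)cc1)c1ccc(-c2ccccc2)cc1` has not yet been measured in this assay. It differs from compound 3 by 4-cyanophenyl in place of 3-chlorophenyl on a saturated ring carbon. Going by the values given here, none of the measured steps touches this part of the molecule: the only step on record, an 8.2-fold higher number from compound 1 to compound 2 (0.92 log units; beyond the scatter), concerns the chain on the amide-type nitrogen, and compounds 1 and 2 both carry an unsubstituted phenyl on the cyclopropane, while compound 3 differs from compound 2 in two places at once, so its gap to compound 2 cannot be assigned to the aryl group alone. With nothing to anchor the change, the step of a 1.1-fold lower number from compound 3 to compound 4 (0.04 log units; within the scatter) is expected to stay within the scatter, with no direction favoured. Compound 4 is therefore estimated at 2000 nM, within a range from 400 nM to 9000 nM.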

Compound 4, half-maximal effective concentration: > 25000 nM
Compound 4 gave a limit, no number (the forecaster's own chance of this, stated with the estimate: 10%); at least 12-fold (1.09 log units) between middle value and limit.
By their numbers in this assay, from the lowest: compound 1; then compound 2; then compound 3. At a limit, above all of these: compound 4.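

In this assay, the aryl group on the cyclopropane turned out to be a place where a single change carries great weight: 4-cyanophenyl in place of 3-chlorophenyl gave an at least 11-fold higher number from compound 3 to compound 4 (1.05 log units; beyond the scatter). Compound 4 gave a limit of the read-out and not a number: the limit of > 25000 nM in this assay, at which 1 of the 4 values shown sits. Going by these compounds alone, this is the first step on record at this position, as the earlier step concerned only the chain on the amide-type nitrogen.

Since the step swaps chlorine for nitrile and also 3- for 4- in the group's name, the compounds shown cannot separate these two changes, and what 3-cyanophenyl or 4-chlorophenyl would give stays open. Also open, on these data alone, is what an unsubstituted phenyl, as in compound 1 and compound 2, or a methoxy group or carboxylic acid on this ring would give with the chain of compound 3.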